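The source may report more compounds than this note shows. Statements on the series, on what has been measured and on what is new or still open speak of the compounds shown alone.

Within the data shown here, in a functional assay on MCF7 cells (Homo sapiens) for antiproliferative activity, read by MTT assay, with a stated time of 72 h (on this read-out lower numbers stand for stronger inhibition and higher numbers for weaker inhibition), compound 3 (`CCN(CC)CCCNC(=O)c1ccc(C(CC)(CC)c2ccc(C#CC(O)(CC)CC)c(C)c2)n1CC`) gives 17800 nM as its reading, the higher of the two actual numbers so far, while compound 1 (`CCN(CC)CCNC(=O)c1ccc(C(CC)(CC)c2ccc(OCC(O)C(C)(C)C)c(C)c2)n1CC`) gives 1370 nM on the same scale. Compound 2 (`CCn1c(C(=O)NCCC(=O)OC)ccc1C(CC)(CC)c1ccc(C#CC(O)(CC)CC)c(C)c1`) gives only > 50000 nM as a limit of the assay, not a number. Compound 4 (`CCn1c(C(=O)NCc2ccc(OC)cc2)ccc1C(CC)(CC)c1ccc(C#CC(O)(CC)CC)c(C)c1`) alters one side chain of compound 3 (4-methoxyphenyl in place of 2-(diethylamino)ethyl on a saturated chain carbon bound to an amide-type nitrogen), with 4-methoxyphenyl in place of 2-(diethylamino)ethyl on a saturated chain carbon bound to an amide-type nitrogen. Among the measured compounds shown here, the one measured step that bears on this is an at least 2.8-fold lower number from compound 2 to compound 3 (0.44 log units; beyond the scatter) where a diethylamino group arrived. Compound 4 has no such group, so a modest move back upward is expected. In this assay this means an expected 2.2-fold higher number from compound 3 to compound 4 (0.35 log units; beyond the scatter) as the likely outcome. The estimate for compound 4 is 40000 nM with an expected range from 15000 nM to 50000 nM in this reading.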

Compound 4, half-maximal inhibitory concentration: > 50000 nM
Compound 4: only a limit was reported; the forecaster's own chance of this, stated with the estimate: 50%; at least 1.2-fold (0.09 log units) between middle value and limit.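

Replacing 3-(diethylamino)propyl with 4-methoxybenzyl in this assay gives an at least 2.8-fold higher number from compound 3 to compound 4 (0.44 log units; beyond the scatter), and the reading for compound 4 is a limit, not a number. Among these compounds, of the three compounds differing only in this side chain, only compound 3, the one carrying the diethylamino group, gives an actual number, so a ring-bearing chain does no better here than the ester chain. The step from compound 2 to compound 4 cannot be read, since both readings are limits: the limit of > 50000 nM in this assay, at which 2 of the 4 values shown sit.

Going by these compounds, what stays open is whether another amine, such as a primary amine or a morpholine at the end of the same chain, would match or improve on compound 3.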